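Trading Ethylamino for Morpholine on the Amide Carbonyl

A few compounds are considered here, and "the series" means these few. Any claim that something is new, unique, unknown or untested is made for them only; others in the source may bear on it.

Compound 1 `CCNC(=O)CC1CCc2cc(OC)c(OC)cc21` carries an ethylamino group on a carbonyl carbon. In a functional assay on the whole organism (strain Wistar) for inhibition, with Rattus norvegicus as the target, read by paw edema, with stated times of 60 min and 4 h, at a dose of 100 mg/kg by the oral route (on this read-out lower numbers stand for less inhibition and higher numbers for more inhibition at the one dose given (going by the name of the read-out)), compound 1 gives 26.6%, the lowest of the three numbers recorded. Compound 2 `CCN(CC)C(=O)CC1CCc2cc(OC)c(OC)cc21` gives 37.5% and compound 3 `COc1cc2c(cc1OC)C(CC(=O)N1CCCCC1)CC2` gives 32%; the step of a number 10.9 percentage points higher from compound 1 to compound 2 (beyond the scatter) lies beyond the scatter, whereas a number 5.4 percentage points higher from compound 1 to compound 3 (within the scatter) and a number 5.5 percentage points lower from compound 2 to compound 3 (within the scatter) do not. Compound 4 `COc1cc2c(cc1OC)C(CC(=O)N1CCOCC1)CC2` differs from compound 1 by morpholin-4-yl in place of ethylamino on a carbonyl carbon. The nearest measured precedent is the step to compound 3, where a six-membered non-aromatic ring likewise replaced ethylamino and the number moved only within the scatter, so at most a small rise is expected here. Compound 4 is therefore estimated at 30%, within 18% to 42%, a step of a number 3.4 percentage points higher from compound 1 to compound 4 (within the scatter).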

Compound 4, a percentage reported as inhibition, in the whole organism at one dose (the size of the read-out at that dose, not a potency): 13.3%
Estimate against measurement, compound 4: 16.7 percentage points above; the measured number lies below the stated range.
By their numbers in this assay, from the lowest: compound 4; then compounds 1, 3 and 2 (each within the scatter of the next, the first and the last beyond it).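

In this assay, morpholin-4-yl in place of piperidin-1-yl on the carbonyl carbon gives a number 18.7 percentage points lower from compound 3 to compound 4 (beyond the scatter), so these two six-membered non-aromatic rings are not interchangeable at this position. Morpholin-4-yl also falls behind both open-chain amides, with a number 13.3 percentage points lower from compound 1 to compound 4 (beyond the scatter) and with a number 24.2 percentage points lower from compound 2 to compound 4 (beyond the scatter), which makes it the first group here to fall beneath the ethylamino compound by more than the scatter.

Going by these compounds, whether a piperazine or thiomorpholine ring on this carbonyl carbon would stay near compound 3 or near compound 4 remains open. Nothing presented here explains the drop.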